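The source may report more compounds than this note shows. Statements on the series, on what has been measured and on what is new or still open speak of the compounds shown alone.

Working notes on the series.

Of the compounds shown here, three have so far been measured in an assay on HEK293 cells for displacement of a labelled ligand from metabotropic glutamate receptor 5 (Homo sapiens), with a stated time of 2 h; a higher number here means a weaker inhibitor, a lower number a stronger inhibitor. Compound 1 `Cc1ccc(C#Cc2ccc3c(n2)CCN(C)C3=O)cc1` gives 7450 nM. Compound 2 `O=C1c2ccc(C#Cc3ccccc3)nc2CCN1C1CCCCC1` gives 12400 nM. Compound 3 `Cc1cccc(C#Cc2ccc3c(n2)CCN(C2CCCCC2)C3=O)c1` gives 3210 nM, the lowest of the three numbers; its gap to compound 1 and its gap to compound 2 both lie beyond the scatter. Within the data shown here, the one single-point step among them, a 3.9-fold lower number from compound 2 to compound 3 (0.59 log units; beyond the scatter), shows that adding a methyl to the aromatic ring on the alkyne is worth a modest gain in this assay.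

Compound 4 `Cc1ccc(C#Cc2ccc3c(n2)CCN(C2CCCCC2)C3=O)cc1` is the next to be measured. It differs from compound 3 by 4-methylphenyl in place of 3-methylphenyl on a triple-bonded carbon. Among the measured compounds shown here, no measured step bears on this change directly: the only pair with a step is compound 2 to compound 3, which adds a methyl rather than moving one, and compound 1, which carries the 4-methylphenyl, differs from compound 3 in a second place as well, so its number cannot be separated into parts. The methyl gain seen in compound 3 may not be kept when the methyl is relocated, so the step of a 1.9-fold higher number from compound 3 to compound 4 (0.27 log units; within the scatter) is expected to run toward a higher number, of a size near the edge of the scatter. Compound 4 is estimated at 6000 nM, within a range of 2500 nM to 15000 nM.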

Compound 4, inhibition constant: 27200 nM
Estimate against measurement, compound 4: 4.5-fold (0.66 log units) below; measured number above the stated range.
By their numbers in this assay, from the lowest: compound 3; then compounds 1 and 2 (each within the scatter of the next); then compound 4.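

Among these compounds, the position of the methyl on the phenyl sets the direction of its effect: the move from 3-methylphenyl to 4-methylphenyl gives an 8.5-fold higher number from compound 3 to compound 4 (0.93 log units; beyond the scatter) and lies well outside what the earlier compounds suggested. Measured against the unsubstituted phenyl, the 4-methylphenyl gives a 2.2-fold higher number from compound 2 to compound 4 (0.34 log units; beyond the scatter) while the 3-methylphenyl gives a 3.9-fold lower number from compound 2 to compound 3 (0.59 log units; beyond the scatter), so the same added methyl moves the number up or down depending on the group it forms. With the 4-methylphenyl held fixed, the group on the amide-type nitrogen in a ring can now be read alone: cyclohexyl in place of methyl gives a 3.7-fold higher number from compound 1 to compound 4 (0.56 log units; beyond the scatter), and nothing on hand explains either this step or the split between the two methylphenyl groups.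

Going by these compounds, whether the 3-methylphenyl keeps its lower number with methyl instead of cyclohexyl on that nitrogen remains open, and so does the reading of the nitrogen step with the 3-methylphenyl in place. On these data alone, how a methoxy group or a chlorine on the phenyl would read in place of the methyl, and how a cyclopentyl or an ethyl would read on the nitrogen, also remains open.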